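This account rests on a few compounds, and the source may have more. Where it says the series, first, only, none or still open, it means among the compounds named here.

Compound 3 `COc1ccc(-c2cc3ccccc3nc2/C=C/C(=O)c2ccc(OC)c(OC)c2)cc1` is measured in a functional assay on A549 cells (Homo sapiens) for antiproliferative activity, read by XTT assay, with a stated time of 72 h (a higher number here means a weaker inhibitor, a lower number a stronger inhibitor), and gives 8860 nM; compound 2 `COc1ccc(-c2cc3ccccc3nc2/C=C/C(=O)c2ccc(OC)cc2OC)cc1` gives 7990 nM, and compound 1 `COc1ccc(-c2cc3ccccc3nc2/C=C/C(=O)c2ccccc2)cc1` gives 7410 nM, so all three sit within the scatter of one another. Compound 4 `COc1ccc(-c2cc3ccccc3nc2/C=C/C(=O)c2ccc(N)cc2)cc1` carries 4-aminophenyl in place of 3,4-dimethoxyphenyl on a carbonyl carbon. Among the measured compounds shown here, the steps that bear on this change all touch the same carbonyl-bound ring: a 1.1-fold higher number from compound 1 to compound 2 (0.03 log units; within the scatter), a 1.2-fold higher number from compound 1 to compound 3 (0.08 log units; within the scatter) and a 1.1-fold higher number from compound 2 to compound 3 (0.04 log units; within the scatter). Each of these exchanges left this assay unmoved beyond the scatter, so no step beyond the scatter is expected for compound 4 either, in either direction. On that basis compound 4 is expected to give 8000 nM in this assay, with a range from 3000 nM to 22000 nM, which means an expected step of a 1.1-fold lower number from compound 3 to compound 4 (0.04 log units; within the scatter).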

Compound 4, half-maximal inhibitory concentration: 7530 nM
Compound 4: the middle estimate sits 1.1-fold (0.03 log units) above what was measured; the range from low to high includes it.
By their numbers in this assay, from the lowest: compounds 1, 4, 2 and 3 (each within the scatter of the next).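

With 4-aminophenyl on the carbonyl carbon, the ring carries a hydrogen-bond donor, yet the number in this assay stays within the scatter of every other compound shown (a 1.2-fold lower number from compound 3 to compound 4 (0.07 log units; within the scatter)), (a 1.1-fold lower number from compound 2 to compound 4 (0.03 log units; within the scatter)) and (a 1.0-fold higher number from compound 1 to compound 4 (0.01 log units; within the scatter)). This position has thus taken an amino group as well as two methoxy patterns without a step beyond the scatter. Nothing here explains why these exchanges leave the number in place. Going by these compounds, whether a carboxylic acid or a longer chain on this ring would give a step beyond the scatter remains open.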